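The source may hold more compounds than are shown below. What is called first, only, known or untested is meant among the compounds shown, and "the series" means these compounds.

Of the compounds shown here, three that share one core have been tested in a functional assay, read by spectrophotometry, with a stated time of 1 h; a lower number here means a stronger inhibitor, a higher number a weaker inhibitor. Compound 1 `Cc1ccc2[nH]c(=O)c(/C=N/c3ccc(C(=O)O)cc3)cc2c1` is recorded in this assay as "not active" (no number reported), and compound 2 `O=c1[nH]c2ccccc2cc1/C=N/c1ccc(O)cc1` likewise as "not active" (no number reported), so neither of them carries a number. Among the compounds with values here, compound 3 `NS(=O)(=O)c1ccc(/N=C/c2cc3ccccc3[nH]c2=O)cc1` is the only member of the set with a measured figure: in this assay compound 3 gives 266000 nM. Compound 3 therefore stands alone on the numbers shown, with nothing measured to compare it against, and no step between two measured compounds can be drawn from these data.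

Compound 4 `Cc1ccc2[nH]c(=O)c(/C=N/c3ccc(S(N)(=O)=O)cc3)cc2c1` has not yet been measured in this assay. Compared with compound 3, the change is methyl in place of hydrogen on an aromatic carbon, on an aromatic carbon of a six-membered aromatic ring of carbon only, part of a fused or bridged system of two rings. Since compound 1 and compound 2 give no number, the set offers no guide to how such a change moves the read-out. A step of the size a 1.1-fold lower number from compound 3 to compound 4 (0.03 log units; within the scatter) is expected, one that stays within the usual scatter and points in no clear direction. Compound 4 is accordingly estimated to give about 250000 nM, with a range from 80000 nM to 800000 nM.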

Compound 4, half-maximal inhibitory concentration: "not active" (no number reported)
Compound 4: no number reported; the estimate stays without a comparison.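

Compound 4 has no number, so no step can be read from compound 3 to compound 4. No measurement shown here offers an explanation for this result. The compounds shown leave open how methyl in place of hydrogen moves the read-out, and how compound 1, compound 2 and compound 4 compare numerically with compound 3.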